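Amide variation on an inert core in HepG2 cells

The source may report more compounds than this note shows. Statements on the series, on what has been measured and on what is new or still open speak of the compounds shown alone.

The series shares the core of compound 1 `C=CCN(C)C(=O)c1ccc(C(CC)(CC)c2ccc(OCCC(O)(CC)CC)c(C)c2)n1CC` and varies the amide attached to it. In a functional assay on HepG2 cells (Homo sapiens) for antiproliferative activity, read by MTT assay, with a stated time of 48 h (on this read-out lower numbers stand for stronger inhibition and higher numbers for weaker inhibition), compound 1 reports only a limit, > 50000 nM. Compound 2 `CCn1c(C(=O)Nc2ccc(OC(F)(F)F)cc2)ccc1C(CC)(CC)c1ccc(OCCC(O)(CC)CC)c(C)c1` likewise reports only a limit in this assay, > 50000 nM. Compound 3 `CCC(C)C(NC(=O)c1ccc(C(CC)(CC)c2ccc(OCCC(O)(CC)CC)c(C)c2)n1CC)C(=O)OC` also reports only a limit in this assay, > 50000 nM. Accordingly a step that the two limits leave unreadable from compound 1 to compound 2, a step that the two limits leave unreadable from compound 1 to compound 3 and a step that the two limits leave unreadable from compound 2 to compound 3 stay unreadable, since all three values sit at the same limit (the limit of > 50000 nM in this assay, at which 3 of the 3 values shown sit).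

Compound 4 `CCC(C)C(NC(=O)c1ccc(C(CC)(CC)c2ccc(OCCC(O)(CC)CC)c(C)c2)n1CC)C(=O)O` differs from compound 1 in one place: (1-carboxy-2-methylbutyl)amino in place of allyl(methyl)amino on a carbonyl carbon. The closest measured neighbour is compound 3, which carries the methyl ester of the same acid and reports only a limit in this assay. With every measured step in this series unreadable and no value below the limit, there is nothing that points to a gain in this assay. Compound 4 is therefore expected to report a limit as well, with a step that the limit leaves unreadable from compound 1 to compound 4, and its estimated value is 60000 nM, in a range from 30000 nM to 150000 nM.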

Compound 4, half-maximal inhibitory concentration: 2620 nM
Compound 4: the middle estimate sits 23-fold (1.36 log units) above what was measured; the measured number lies below the stated range.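

In this assay, the position on the carbonyl carbon proves able to respond: hydrogen in place of methyl on an oxygen next to a carbonyl group gives an at least 19-fold lower number from compound 3 to compound 4 (1.28 log units; beyond the scatter). The (1-carboxy-2-methylbutyl)amino group in place of allyl(methyl)amino gives an at least 19-fold lower number from compound 1 to compound 4 (1.28 log units; beyond the scatter), and 1-carboxy-2-methylbutyl in place of 4-(trifluoromethoxy)phenyl on an amide-type nitrogen gives an at least 19-fold lower number from compound 2 to compound 4 (1.28 log units; beyond the scatter). Among the compounds shown, only the one holding the free carboxylic acid gives a value that is not a limit, while the others remain at it: the limit of > 50000 nM in this assay, at which 3 of the 4 values shown sit.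

The compounds shown leave open whether the carboxylic acid alone accounts for the step or whether the 2-methylbutyl part of the chain also contributes. An acid on a shorter chain, such as the glycine amide, or a primary amide in place of the acid, would address that question.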